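The source may report more compounds than this note shows. Statements on the series, on what has been measured and on what is new or still open speak of the compounds shown alone.

Measured so far, in an ADME assay for pharmacokinetics, read by LC-MS, in phosphate buffer, with a stated time of 72 h, at pH 7.4, tested at 250 uM; a higher number here means that the compound lasts longer, a lower number that the compound disappears faster: compound 1 `O=C1C=CC(=O)N1c1cc(C(F)(F)F)cc(C(F)(F)F)c1` gives < 0.017 h, which is a limit of the assay. Compound 2 `C#Cc1cc(C(F)(F)F)cc(C(F)(F)F)c1` gives > 50 h, also a limit. Compound 3 `N#Cc1cc(C(F)(F)F)cc(C(F)(F)F)c1` gives > 50 h, again a limit.

Compound 3 therefore stands at the upper edge of what this assay reports, (the limit of > 50 h in this assay, at which 2 of the 3 values shown sit), and its true half-life is not known beyond that. Compound 4 `O=C(CBr)c1cc(C(F)(F)F)cc(C(F)(F)F)c1` differs from it in one place: (bromomethyl)carbonyl in place of cyano on an aromatic carbon. Among the compounds with values here, two measured steps bear on this position. The step of an at least 2900-fold higher number from compound 1 to compound 3 (3.46 log units; beyond the scatter) shows that a change of the group there can move the half-life very far, while a step that the two limits leave unreadable from compound 2 to compound 3. A large downward step from compound 3 to compound 4 is expected, an at least 6.2-fold lower number from compound 3 to compound 4 (0.79 log units; beyond the scatter), and compound 4 is estimated at 8 h, between 1 h and 50 h.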

Compound 4, half-life: < 0.017 h
Compound 4 was reported as a limit (the forecaster's own chance of this, stated with the estimate: 20%); at least 470-fold (2.67 log units) between middle value and limit.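

In this assay, putting (bromomethyl)carbonyl at this position gives an at least 2900-fold lower number from compound 3 to compound 4 (3.46 log units; beyond the scatter), and an at least 2900-fold lower number from compound 2 to compound 4 (3.46 log units; beyond the scatter). Earlier, only compound 1, whose group holds a five-membered ring, sat at the low end; compound 4 shows that a group with no ring can sit there too. The step between compound 1 and compound 4 cannot be read, because both values are limits: the limit of < 0.017 h in this assay, at which 2 of the 4 values shown sit.

Every value shown is a limit, so no half-life at this position is yet a true number. Open, going by these compounds, is whether an amine, or an acetyl group with hydrogen in place of the bromine, would fall between the two limits.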